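Adding a Methyl to the Chain of Compound 2

A few compounds are considered here, and "the series" means these few. Any claim that something is new, unique, unknown or untested is made for them only; others in the source may bear on it.

In a functional assay on A549 cells (Homo sapiens) for antiproliferative activity, read by MTT assay, with a stated time of 48 h (on this read-out higher numbers stand for weaker inhibition and lower numbers for stronger inhibition), compound 1 (`Cc1ccc(Nc2ccc3c(c2)C(O)(CCC(C)C)C(=O)N3)cc1`) gives 12500 nM, while compound 2 (`CCCCC1(O)C(=O)Nc2ccc(Nc3ccc(Cl)cc3)cc21`) gives 2800 nM, the lower of the two numbers by a gap beyond the scatter. Compound 3 (`CC(C)CCC1(O)C(=O)Nc2ccc(Nc3ccc(Cl)cc3)cc21`) departs from compound 2 by methyl in place of hydrogen on a saturated chain carbon bound to two saturated chain carbons, which turns butyl into isopentyl. Among the compounds with values here, no measured pair isolates this change, so only a small shift is expected in this assay, none beyond the scatter. The estimated step is a 1.1-fold lower number from compound 2 to compound 3 (0.05 log units; within the scatter). The expected value for compound 3 is 2500 nM, within a range of 1000 nM to 6500 nM.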

Compound 3, half-maximal inhibitory concentration: 2700 nM
Compound 3: middle estimate off by 1.1-fold (0.03 log units), on the low side; the range from low to high includes it.
By their numbers in this assay, from the lowest: compounds 3 and 2 (each within the scatter of the next); then compound 1.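

In this assay the step from butyl to isopentyl, a 1.0-fold lower number from compound 2 to compound 3 (0.02 log units; within the scatter), leaves the number within the scatter, so this saturated chain carbon tolerates a methyl in place of hydrogen. With isopentyl now common to both, chloro in place of methyl on an aromatic carbon can be read alone: a 4.6-fold lower number from compound 1 to compound 3 (0.67 log units; beyond the scatter), a step beyond the scatter. No measurement at hand accounts for either step. Still open, on these data alone, is how a longer chain or an amine on the chain would read, and whether methoxy or fluoro on that aromatic carbon would match chloro.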